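Cytotoxicity notes on four related compounds

The compounds below may be only part of what the source reports. "The series", "measured", "known", "first", "only" and "open" are said of these compounds alone.

Compound 1 `c1ccc(CNc2nc(Nc3ccccc3)nc3ccccc23)cc1` was tested in an ADME assay on C2C12 cells (Mus musculus) for cytotoxicity; on this read-out lower numbers stand for higher toxicity in this test and higher numbers for lower toxicity in this test. In this assay compound 1 gives > 10000 nM, which is a limit of the assay and not a number. Compound 2 `Clc1ccc(Nc2nc(NCc3ccccc3)c3ccccc3n2)cc1` differs from compound 1 by chloro in place of hydrogen on an aromatic carbon. In this assay compound 2 gives 10000 nM. The step of a number no higher from compound 1 to compound 2 (the limit leaves the size open) has no readable size because the limit of > 10000 nM in this assay, at which 2 of the 3 values shown sit, covers one of its two values.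

Compound 3 `c1ccc(CNc2ccnc(Nc3ccccc3)n2)cc1` has a different core from compound 1; the difference between the two cores is not broken down here. In this assay compound 3 gives > 10000 nM, again a limit of the assay rather than a number.

Compound 4 `Clc1ccc(Nc2nccc(NCc3ccccc3)n2)cc1` is not yet measured in this assay. It differs from compound 3 by chloro in place of hydrogen on an aromatic carbon, the same change already seen in this set, at the same kind of place. For compound 4 a step of a number no higher from compound 3 to compound 4 (the limit leaves the size open) is expected, resting on the step of a number no higher from compound 1 to compound 2 (the limit leaves the size open) that left the size open. Compound 4 is therefore estimated at 10000 nM, between 5000 nM and 20000 nM, with a real chance that only a limit is returned.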

Compound 4, half-maximal cytotoxic concentration: > 10000 nM
Compound 4: only a limit was reported; the forecaster's own chance of this, stated with the estimate: 60%; the middle value sits exactly at the limit.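

No size can be read for the step from compound 3 to compound 4 in this assay, because both compounds return only a limit of the assay and not a number: the limit of > 10000 nM in this assay, at which 3 of the 4 values shown sit.

The compounds shown leave open whether chloro in place of hydrogen on an aromatic carbon changes this read-out on the core of compound 3.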